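This account rests on a few compounds, and the source may have more. Where it says the series, first, only, none or still open, it means among the compounds named here.

Three compounds have been measured so far:

Compound 1 `CC(C)N(Cc1cccc(OCCCCCC(=O)O)c1)C(=O)c1ccc(-c2ccncc2)cc1`: in an ADME assay on HEK293 cells (Homo sapiens) for cytotoxicity, read by CellTiter-Glo and resazurin assay, with a stated time of 72 h (on this read-out higher numbers stand for an effect only at larger amounts of compound and lower numbers for an effect already at smaller amounts), compound 1 is reported only as the limit > 26000 nM.
Compound 2 `CCOC(=O)CCCCCOc1cccc(CN(C(=O)c2ccc(-c3ccncc3)cc2)C(C)C)c1`: in this assay compound 2 is reported only as the limit > 26000 nM.
Compound 3 `CCOC(=O)CCCCCOc1cccc(CN(C(=O)c2ccc(-c3cc4ccccc4n3S(=O)(=O)c3ccccc3)cc2)C(C)C)c1`: in this assay compound 3 is reported only as the limit > 26000 nM.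

For the measured compounds named here, compound 2 therefore stands at the limit, as do the other two; every value shown sits at the limit of > 26000 nM in this assay, at which 3 of the 3 values shown sit, so no compound shows any toxic effect within the tested range. Going by the values given here, the one step that can be traced, a step that the two limits leave unreadable from compound 1 to compound 2, is unreadable, since both ends of it are limits rather than numbers.

Compound 4 `CCOC(=O)CCCCCOc1cccc(CN(C(=O)c2ccc(-c3cccc(OC(F)(F)F)c3)cc2)C(C)C)c1` has not yet been measured. It differs from compound 2 in one place: 3-(trifluoromethoxy)phenyl in place of pyridin-4-yl on an aromatic carbon. Among the compounds with values here, no measured step involves a change of this kind, so there is no direct comparison to draw on. What the data do show is that compounds of this core, whether carrying the free acid, the ethyl ester or a much larger aromatic group, all stay at the limit. On that basis the step from compound 2 to compound 4 is expected to be a step that the limit leaves unreadable from compound 2 to compound 4, that is, nothing readable. Compound 4 is accordingly estimated at 30000 nM in this assay, within 12000 nM to 80000 nM, and most likely reported again only as a limit.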

Compound 4, half-maximal effective concentration: > 26000 nM
Compound 4: a limit, no number (the forecaster's own chance of this, stated with the estimate: 80%); the middle value is on the limit's open side.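

In this assay, compound 2 and compound 4 are both reported only as limits rather than numbers, so no step can be read between them, and all the compounds shown share one reading: the limit of > 26000 nM in this assay, at which 4 of the 4 values shown sit. What stays open is the concentration at which any of these compounds would affect the cells, and whether the changes compared here alter it.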